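From hydroxymethyl to diacetoxymethyl on a shared core

A few compounds are considered here, and "the series" means these few. Any claim that something is new, unique, unknown or untested is made for them only; others in the source may bear on it.

Compound 1 `COc1cc(O)c2c(c1O)C[C@]1(C)O[C@@H]1CC[C@@]1(C)O[C@@H]1C2=O` gives 17000 nM
Compound 2 `COc1cc(O)c2c(c1O)C/C(C)=C\CC[C@@]1(C)O[C@@H]1C2=O` gives 15000 nM
Compound 3 `COc1cc(O)c2c(c1O)C/C(CO)=C\CC[C@@]1(C)O[C@@H]1C2=O` gives 43000 nM

All three were measured in a functional assay on MCF7 cells (Homo sapiens) for antiproliferative activity, read by WST assay, with a stated time of 5 days (a lower number here means a stronger inhibitor, a higher number a weaker inhibitor), and compound 3 has the highest number of the three, with gaps to compound 1 and compound 2 that lie beyond the scatter. Compound 4 (`COc1cc(O)c2c(c1O)C/C(C(OC(C)=O)OC(C)=O)=C\CC[C@@]1(C)O[C@@H]1C2=O`) differs from compound 3 in one group (diacetoxymethyl in place of hydroxymethyl on a double-bonded ring carbon) with diacetoxymethyl in place of hydroxymethyl on a double-bonded ring carbon. Among the compounds with values here, one measured step bears on this change (a 2.9-fold higher number from compound 2 to compound 3 (0.46 log units; beyond the scatter)) with hydroxy in place of hydrogen on a saturated chain carbon bound to a double-bonded ring carbon, and that step was modest but beyond the scatter. Within the data shown here, compound 4 has no hydroxy there, so a modest step to a lower number is expected in this assay as a tentative move back toward compound 2 at 15000 nM but no measured compound carries diacetoxymethyl, so the range stays wide. The expected move is a 2.0-fold lower number from compound 3 to compound 4 (0.29 log units; within the scatter) on this reasoning. For compound 4 the estimated value is 22000 nM with an expected range (8000 nM to 60000 nM).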

Compound 4, half-maximal inhibitory concentration: 5600 nM
For compound 4 the middle estimate is 3.9-fold (0.59 log units) above the measured one; measured number outside the range, below it.
By their numbers in this assay, from the lowest: compound 4; then compounds 2 and 1 (each within the scatter of the next); then compound 3.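

In this assay, putting diacetoxymethyl in place of hydroxymethyl on the double-bonded ring carbon gives a 7.7-fold lower number from compound 3 to compound 4 (0.89 log units; beyond the scatter) and so reverses the rise seen earlier with a 2.9-fold higher number from compound 2 to compound 3 (0.46 log units; beyond the scatter) at this position. The change does more than undo that rise, since diacetoxymethyl in place of methyl gives a 2.7-fold lower number from compound 2 to compound 4 (0.43 log units; beyond the scatter) and shows that a much larger group on this carbon can go with a lower number than either smaller group. No measurement shown here explains why diacetoxymethyl has this effect.

Going by these compounds, it remains open whether the full diacetoxymethyl group is needed, or whether an acetoxymethyl group or an aldehyde on this carbon would give a similar number. An amine or a carboxylic acid there would test whether the lower number extends to quite different groups.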